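Replacing thiophen-2-yl in compound 3 with (1H-indol-3-yl)methyl

The compounds below may be only part of what the source reports. "The series", "measured", "known", "first", "only" and "open" are said of these compounds alone.

Among the measured compounds shown here, in a functional assay on L5178Y cells (Mus musculus) for inhibition, read by MTT assay, with a stated time of 24 h (a lower number here means a stronger inhibitor, a higher number a weaker inhibitor), compound 3 `COc1cc(O)c2c(c1)O[C@H](c1ccc(O)cc1)C/C2=N\NC(=O)c1cccs1` gives 9400 nM, the only actual number among the three measured compounds. Compound 1 `O=C(N/N=C1\C[C@@H](c2ccc(O)cc2)Oc2cc(O)cc(O)c21)c1cccs1` reads >= 11300 nM, which is a limit of the assay. Compound 2 `COc1cc(O)c2c(c1)O[C@H](c1ccc(O)cc1)C/C2=N\Nc1ccccc1` reads >= 11300 nM, also a limit. Compound 4 `COc1cc(O)c2c(c1)O[C@H](c1ccc(O)cc1)C/C2=N\NC(=O)Cc1c[nH]c2ccccc12` carries (1H-indol-3-yl)methyl in place of thiophen-2-yl on a carbonyl carbon. Two measured steps offer guidance: an at least 1.2-fold lower number from compound 2 to compound 3 (0.07 log units; that floor lies within the scatter), which also changes the group on an amine nitrogen, and an at least 1.2-fold lower number from compound 1 to compound 3 (0.07 log units; that floor lies within the scatter), which adds a methyl in place of hydrogen on an oxygen on an aromatic ring. Both floors lie within the scatter, and neither measures this exchange, so no shift beyond the scatter is expected in this assay. The expected change is a 1.0-fold lower number from compound 3 to compound 4 (0.02 log units; within the scatter). For compound 4 the estimate is 9000 nM, with an expected range of 3500 nM to 20000 nM.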

Compound 4, half-maximal inhibitory concentration: >= 11300 nM
Compound 4 ended at the assay's limit; the forecaster's own chance of this, stated with the estimate: 35%; middle value at least 1.2-fold (0.09 log units) away from the limit.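

In this assay the exchange of thiophen-2-yl for (1H-indol-3-yl)methyl on the carbonyl carbon gives an at least 1.2-fold higher number from compound 3 to compound 4 (0.07 log units; that floor lies within the scatter) and is the only step shown at this place. The larger group, with its hydrogen-bond donor, therefore brings no shift beyond the scatter. The value of compound 4 is a limit and not a number, so the true size of the step stays unknown, and the series largely sits at that limit: the limit of >= 11300 nM in this assay, at which 3 of the 4 values shown sit.

From the compounds shown here alone, whether an amine or a carboxylic acid on this carbonyl carbon would move the number beyond the scatter stays open. So does whether a longer chain ending in thiophen-2-yl would.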